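Shortening the chain and enlarging the sulfonyl group

The source may hold more compounds than are shown below. What is called first, only, known or untested is meant among the compounds shown, and "the series" means these compounds.

Measured so far:
Compound 1, `CS(=O)(=O)NC(=O)CCc1cn(-c2ccc(Br)cc2)nc1-c1ccc(Cl)cc1`, gives 170000 nM in a physicochemical assay for solubility, in phosphate buffer, measured as thermodynamic solubility, at pH 7.4; on this read-out higher numbers stand for higher solubility and lower numbers for lower solubility.
Compound 2, `CS(=O)(=O)NC(=O)CCCc1cn(-c2ccc(Br)cc2)nc1-c1ccc(Cl)cc1`, gives 135000 nM in this assay.

For the measured compounds named here, compound 2 holds the lowest of the two numbers, yet its only neighbour, compound 1, is separated from it by a 1.3-fold lower number from compound 1 to compound 2 (0.10 log units; within the scatter), so the two stand level within the scatter. Compound 3, `O=C(CCc1cn(-c2ccc(Br)cc2)nc1-c1ccc(Cl)cc1)NS(=O)(=O)C1CC1`, is not yet measured. It differs from compound 2 in one place: (cyclopropylsulfonyl)carbamoyl in place of ((methylsulfonyl)carbamoyl)methyl on a saturated chain carbon, two bonds along the chain from an aromatic carbon. The chain length returns to that of compound 1 while the sulfonyl substituent changes. Going by the values given here, the one measured step that bears on the chain, a 1.3-fold lower number from compound 1 to compound 2 (0.10 log units; within the scatter), was within the scatter. Among the compounds with values here, no measured pair speaks to the new sulfonyl substituent. The expectation in this assay is therefore a step of a 1.1-fold higher number from compound 2 to compound 3 (0.05 log units; within the scatter), no change beyond the scatter. Compound 3 is estimated to give 150000 nM, with a range from 70000 nM to 320000 nM.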

Compound 3, solubility: 5000 nM
The estimate for compound 3 lay 30-fold (1.48 log units) above the measured number; measured number below the stated range.
By their numbers in this assay, from the lowest: compound 3; then compounds 2 and 1 (each within the scatter of the next).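

In this assay, the group on the sulfonyl sulfur turns out to matter far more than the chain: cyclopropyl in place of methyl, with the chain left as it is, gives a 34-fold lower number from compound 1 to compound 3 (1.53 log units; beyond the scatter). The step of a 27-fold lower number from compound 2 to compound 3 (1.43 log units; beyond the scatter) is also large, although it changes the chain as well, while the chain change alone gave only a 1.3-fold lower number from compound 1 to compound 2 (0.10 log units; within the scatter). Nothing available here explains why so small a change in the sulfonyl group has so large a result.

An ethyl or isopropyl group on the sulfonyl sulfur would help show whether the drop belongs to the three-membered ring itself or extends to other groups in place of methyl. From the compounds shown here alone, it also remains open whether cyclopropyl on the longer chain of compound 2 would bring the same drop.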